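Trimming the Chain of Compound 3

A few compounds are considered here, and "the series" means these few. Any claim that something is new, unique, unknown or untested is made for them only; others in the source may bear on it.

Of the compounds shown here, three on a shared core have been tested in a functional assay on HepG2 cells (Homo sapiens) for cytotoxicity, with a stated time of 72 h (a higher number here means that more compound is needed for the effect, a lower number that less compound is needed), and none of them gives a number. Compound 1 (`C=C[C@@](C)(/C=C/c1ccc(OC)cc1)CCC=C(C)C`) reads > 52000 nM as a limit of the assay. Compound 2 (`C=C[C@](C)(CCCC(C)C)CCc1ccc(O)cc1`) reads > 52000 nM as a limit as well. Compound 3 (`C=C[C@@](C)(/C=C/c1ccc(O)cc1)CCC(O)C(C)(C)O`) reads > 52000 nM as a limit too. Compound 3 therefore stands where the other two stand, and no measured number ranks any of them. Among the compounds with values here, no two tested compounds differ in only one place, so no measured step is available as a guide.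

Compound 4 (`C=C[C@@](C)(/C=C/c1ccc(O)cc1)CCCO`) comes from compound 3 through a single change. The change is hydrogen in place of 1-hydroxy-1-methylethyl on a saturated chain carbon bound to an oxygen on a saturated carbon and a saturated chain carbon with hydrogen in place of 1-hydroxy-1-methylethyl on a saturated chain carbon bound to an oxygen on a saturated carbon and a saturated chain carbon.

Within the data shown here, the expectation rests on compound 3, whose > 52000 nM is a limit, and on the limit of > 52000 nM in this assay, at which 3 of the 3 values shown sit, as the only guide. No change beyond the scatter is expected in this assay and the estimated shift is a step that the limit leaves unreadable from compound 3 to compound 4 in no firm direction. For compound 4 the estimated value is 60000 nM with an expected range from 35000 nM to 100000 nM in this reading, and a report of only a limit is the likeliest outcome.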

Compound 4, half-maximal effective concentration: > 52000 nM
Compound 4: no number, only a limit; the forecaster's own chance of this, stated with the estimate: 85%; the middle value does not contradict the limit.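

No new step can be read between compound 3 and compound 4 in this assay, because both give only a limit and no number: the limit of > 52000 nM in this assay, at which 4 of the 4 values shown sit.

The compounds shown leave open whether any compound on the shared core reaches a measurable value in this assay, and whether 1-hydroxy-1-methylethyl on that chain makes any difference there.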